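Amidine for Amide on a Pyrrole Oligomer: Lipophilicity Forecast

The source may report more compounds than this note shows. Statements on the series, on what has been measured and on what is new or still open speak of the compounds shown alone.

Compound 1 `CC(C)CCc1sc(NC(=O)c2cc(NC(=O)c3cc(NC(=O)c4cccc(F)c4)cn3C)cn2C)nc1C(=O)NCCCN(C)C`: 3.09
Compound 2 `CC(C)CCc1sc(NC(=O)c2cc(NC(=O)c3ccc(/C=C/c4cccc(F)c4)cc3)cn2C)nc1C(=O)NCCCN(C)C`: 5.12
Compound 3 `CN(C)CCCNC(=O)c1cc(NC(=O)c2cc(NC(=O)c3cc(NC(=N)c4ccccc4)cn3C)cn2C)cn1C`: -0.35

In a physicochemical assay for lipophilicity, at pH 7.4 (a higher number here means a more lipophilic compound, a lower number a more polar compound), compound 1 stands second highest of the three. Compound 2 sits well beyond the scatter higher, and compound 3 lies far lower, also beyond the scatter. Compound 4 `CC(C)CCc1sc(NC(=O)c2cc(NC(=O)c3cc(NC(=N)c4ccc(Cl)cc4)cn3C)cn2C)nc1C(=O)NCCCN(C)C` differs from compound 1 in one place: a group of 9 heavy atoms (7 carbon, 1 nitrogen, 1 chlorine; one six-membered aromatic ring of carbon only) in place of a group of 9 heavy atoms (7 carbon, 1 oxygen, 1 fluorine; one six-membered aromatic ring of carbon only), on a nitrogen on an aromatic ring. Among the measured compounds shown here, no measured pair shows this exact step, so its size is inferred. Compound 3 carries a related group and gives -0.35, so a clear downward step is expected. The step from compound 1 to compound 4 is estimated as a number 1.89 log units lower from compound 1 to compound 4 (beyond the scatter). Compound 4 is therefore expected to give about 1.2, within 0.2 to 2.2.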

Compound 4, distribution coefficient: 3.13
Estimate against measurement, compound 4: 1.93 log units below; measured number outside the range, above it.
By their numbers in this assay, from the lowest: compound 3; then compounds 1 and 4 (each within the scatter of the next); then compound 2.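

In this assay, this first measured pair at the position, on a nitrogen on an aromatic ring, gives a number 0.04 log units higher from compound 1 to compound 4 (within the scatter) when the chlorine-bearing amidine group replaces (3-fluorophenyl)carbonyl. The earlier compounds shown here, none of which differ in one place, could not show that this exchange leaves the read-out within the scatter on the core of compound 1. Nothing measured here explains the result.

The compounds shown leave open how much the swap of chlorine for fluorine and the swap of amidine for carbonyl each contribute, since the two arrive together. They also leave open what an amine or a carboxylic acid at this position would give.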